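A few compounds are considered here, and "the series" means these few. Any claim that something is new, unique, unknown or untested is made for them only; others in the source may bear on it.

Compound 1 `O=C(Nc1ccc(Oc2ccnc3[nH]ccc23)cc1)c1nn(-c2ccc(Cl)c(F)c2)ccc1=O` gives 3110 nM in a functional assay on MCF7 cells (Homo sapiens) for cytotoxicity, read by MTT assay, with a stated time of 72 h; on this read-out lower numbers stand for stronger inhibition and higher numbers for weaker inhibition.
Compound 2 `Cn1ccc2c(Oc3ccc(NC(=O)c4nn(-c5ccc(Cl)c(F)c5)ccc4=O)cc3)ccnc21` gives 16800 nM in this assay.
Compound 3 `Cn1ccc2c(Oc3ccc(NC(=O)c4nn(-c5ccc(Cl)c(C(F)(F)F)c5)ccc4=O)cc3)ccnc21` gives 15200 nM in this assay.

Among these three numbers compound 2 stands highest. Its nearest neighbour is compound 3, separated by a 1.1-fold lower number from compound 2 to compound 3 (0.04 log units; within the scatter), and its furthest is compound 1, separated by a 5.4-fold higher number from compound 1 to compound 2 (0.73 log units; beyond the scatter).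

Compound 4 `Cn1ccc2c(Oc3ccc(NC(=O)c4nn(-c5ccc(Cl)c(F)c5)ccc4=O)cc3F)ccnc21` has not yet been measured. It differs from compound 2 in one place: fluoro in place of hydrogen on an aromatic carbon. Among the compounds with values here, none of the measured steps introduces a fluoro onto this ring, so the comparison is indirect. The step of a 1.1-fold lower number from compound 2 to compound 3 (0.04 log units; within the scatter) is the closest parallel, an exchange of one small substituent for another on an aromatic carbon, and it stayed within the scatter. The step of a 5.4-fold higher number from compound 1 to compound 2 (0.73 log units; beyond the scatter) concerns a different part of the molecule, a methyl on an aromatic nitrogen, and does not bear directly on the change in hand.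

On that basis the expected step in this assay is small, in no definite direction, and most likely within the scatter. Compound 4 is therefore estimated at 14000 nM, with a range from 6000 nM to 35000 nM. This estimate corresponds to an expected step of a 1.2-fold lower number from compound 2 to compound 4 (0.08 log units; within the scatter).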

Compound 4, half-maximal inhibitory concentration: 16600 nM
Estimate against measurement, compound 4: 1.2-fold (0.07 log units) below; the range from low to high includes it.
By their numbers in this assay, from the lowest: compound 1; then compounds 3, 4 and 2 (each within the scatter of the next).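

On this ring of carbon only, a fluoro in place of hydrogen, ortho to a large group and meta to a large group, gives a 1.0-fold lower number from compound 2 to compound 4 (0.01 log units; within the scatter) in this assay, so this single added atom leaves the read-out where it was and shows that this position can carry a fluoro without a change beyond the scatter. Earlier compounds had offered no test of this ring, since their steps concerned other parts of the molecule, and this step now stands with a 1.1-fold lower number from compound 2 to compound 3 (0.04 log units; within the scatter) as a second change on an aromatic carbon that stays within the scatter, while among the steps shown only a 5.4-fold higher number from compound 1 to compound 2 (0.73 log units; beyond the scatter) goes beyond it. No measurement among those given accounts for this flat result.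

The compounds shown leave open whether a larger group at this position, such as a methoxy or an amine, would move the number as a fluoro does not. They also leave open whether the same fluoro would behave alike in compound 1, which keeps the hydrogen on the aromatic nitrogen and has the lowest number of the set.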